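The source may report more compounds than this note shows. Statements on the series, on what has been measured and on what is new or still open speak of the compounds shown alone.

Measured compounds:
- Compound 1 `CCCn1c(=O)n(CCOCC)c(=O)c2[nH]cnc21` gives 70 nM in a functional assay (trachea) with Cavia porcellus as the target; a higher number here means that more compound is needed for the effect, a lower number that less compound is needed.
- Compound 2 `CCCn1c(=O)n(CC(C)=O)c(=O)c2[nH]cnc21` gives 14900 nM in this assay.
- Compound 3 `CCCn1c(=O)n(C)c(=O)c2c1ncn2CCOCC` gives 4600 nM in this assay.

Compound 1 and compound 2 differ in one place only: acetyl in place of ethoxymethyl on a saturated chain carbon bound to an aromatic nitrogen. That change alone gave a 210-fold higher number from compound 1 to compound 2 (2.33 log units; beyond the scatter), a large loss of effect, so that compound 2 needs far more material than compound 1 to relax the tissue.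

Compound 3 carries the same ethoxymethyl-bearing chain, but its core differs from the core of compound 1; the difference between the two cores is not broken down here. What the numbers show is that compound 3 already needs much more compound than compound 1, though less than compound 2.

Compound 4 `CCCn1c(=O)n(C)c(=O)c2c1ncn2CC(C)=O` has not yet been measured. It relates to compound 3 as compound 2 relates to compound 1: acetyl in place of ethoxymethyl on a saturated chain carbon bound to an aromatic nitrogen. The place of the change is the same in both pairs, so this is the same change made on a different core.

Among the compounds with values here, because the one measured example of this change gave a 210-fold higher number from compound 1 to compound 2 (2.33 log units; beyond the scatter), compound 4 is expected to need more material than compound 3, though a step of the same size would carry it far out of the range where numbers are usually reported. For compound 4 the expected step is a 13-fold higher number from compound 3 to compound 4 (1.12 log units; beyond the scatter). Compound 4 is thus estimated at 60000 nM, somewhere between 15000 nM and 300000 nM.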

Compound 4, half-maximal effective concentration: 1900 nM
Beside the measured number, compound 4's estimate is 32-fold (1.50 log units) above it, and the stated range ends above it.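

In this assay, putting acetyl in place of ethoxymethyl on the core of compound 3 gave a 2.4-fold lower number from compound 3 to compound 4 (0.38 log units; beyond the scatter), a modest gain in effect, whereas the same swap on the core of compound 1 gave a 210-fold higher number from compound 1 to compound 2 (2.33 log units; beyond the scatter), a large loss. The outcome of this change therefore depends on the core that carries it, and a result from one core cannot simply be carried over to the other; the two steps run in opposite directions, and the gap between them is larger than repeated measurements would explain: the same change on two cores in this assay, a 210-fold higher number (2.33 log units; beyond the scatter) from compound 1 to compound 2 and a 2.4-fold lower number (0.38 log units; beyond the scatter) from compound 3 to compound 4, 520-fold (2.71 log units) apart, beyond the scatter of two such steps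

This does not show why the cores respond differently, and with a single pair on each core it gives no general rule for the change, only a warning against assuming that it transfers.

Going by these compounds, it remains open whether the same reversal would appear with other groups at this place, such as a longer chain, an amine or a carboxylic acid. Also open, on these data alone, is which part of the difference between the two cores decides the direction of the step.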